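Reversing a methylene linker on a bicyclic lactam series

A few compounds are considered here, and "the series" means these few. Any claim that something is new, unique, unknown or untested is made for them only; others in the source may bear on it.

Compounds with their measured values: compound 1 `CC(C)(O)c1ccc(-c2cnc3c(n2)N(CCC2CCOCC2)C(=O)CN3)cn1` gives 78%; compound 2 `CO[C@H]1CC[C@@H](N2CC(=O)Nc3ncc(-c4ccc(C(C)(C)O)nc4)nc32)CC1` gives 59%; compound 3 `CO[C@H]1CC[C@H](CN2CC(=O)Nc3ncc(-c4ccc(C(C)(C)O)nc4)nc32)CC1` gives 55%.

In a functional assay on the whole organism (PC-3 cells) for inhibition, with Mus musculus as the target, in a xenograft, with a stated time of 8 h, at a dose of 100 mg/kg by the oral route (a lower number here means less inhibition, a higher number more inhibition at the dose given (going by the name of the read-out)), compound 3 gives the lowest of the three numbers. Its nearest neighbour is compound 2, whose value lies within the scatter of it, while compound 1 sits beyond the scatter above both. The step from compound 2 to compound 3 was a number 4 percentage points lower from compound 2 to compound 3 (within the scatter), so lengthening the link by one carbon changed nothing that can be trusted.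

Compound 4 `CO[C@H]1CC[C@H](N2CC(=O)Nc3ncc(-c4ccc(C(C)(C)O)nc4)nc32)CC1` undoes that change: 4-methoxycyclohexyl in place of (4-methoxycyclohexyl)methyl on a nitrogen on an aromatic ring in a ring. The entering group is the same one that compound 2 carries, though the two stereocentres are set differently, and nothing measured here speaks to that difference. Among the measured compounds shown here, the one bearing step, from compound 2 to compound 3, was within the scatter, so its reversal is expected to be within the scatter as well, estimated as a number 4 percentage points higher from compound 3 to compound 4 (within the scatter) in this assay. Compound 4 is therefore expected to give about 59%, with a range from 44% to 74%.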

Compound 4, a percentage reported as inhibition, in the whole organism at one dose (the size of the read-out at that dose, not a potency): 69%
Estimate against measurement, compound 4: 10 percentage points below; the measured number falls inside the stated range.
By their numbers in this assay, from the lowest: compounds 3, 2, 4 and 1 (each within the scatter of the next, the first and the last beyond it).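

In this assay, the shorter link at this position, on a nitrogen on an aromatic ring in a ring, now gives a step that can be read: a number 14 percentage points higher from compound 3 to compound 4 (beyond the scatter). Among the compounds shown here, the earlier step, a number 4 percentage points lower from compound 2 to compound 3 (within the scatter), had stayed inside the scatter, so compound 4 is the first sign that this change of link can register at all, and that sign rests on one pair. Inverting both stereocentres does not separate the two compounds with the shorter link, a number 10 percentage points higher from compound 2 to compound 4 (within the scatter), and this pair isolates configuration alone: the fact that compounds 2 and 4 differ only in the configuration as drawn.

The compounds shown leave open how (4-methoxycyclohexyl)methyl behaves with its stereocentres inverted, so link length and configuration cannot be fully separated. They also leave open what an amine or a hydroxyl in place of the methoxy of 4-methoxycyclohexyl would give.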